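This account rests on a few compounds, and the source may have more. Where it says the series, first, only, none or still open, it means among the compounds named here.

Working notes on the series.

Compound 1 `COc1cccc(Cc2cn(C3CC3)c3c(F)c(-c4cc(C)nc(C)c4)c(F)cc3c2=O)c1` is the weaker of the two measured compounds: in a functional assay on P388 cells (Mus musculus) for cytotoxicity (a lower number here means a stronger inhibitor, a higher number a weaker inhibitor), compound 1 gives 20000 nM, the highest of the two numbers. Compound 2 `Cc1cc(-c2c(F)cc3c(=O)c(Cc4ccccc4)cn(C4CC4)c3c2F)cc(C)n1` gives 7300 nM in this assay. For the measured compounds named here, the only measured step, a 2.7-fold lower number from compound 1 to compound 2 (0.44 log units; beyond the scatter), shows that taking the methoxy off the aromatic carbon lowers the number modestly but beyond the scatter.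

Compound 3 `Cc1cc(-c2c(F)cc3c(=O)c(Cc4ccc(O)cc4)cn(C4CC4)c3c2F)cc(C)n1` is not yet measured. It differs from compound 1 by 4-hydroxyphenyl in place of 3-methoxyphenyl on a saturated chain carbon bound to an aromatic carbon. Going by these compounds, the step from compound 1 to compound 2 bears on this change in part, since it also removes the methoxy; nothing measured speaks to what the entering hydroxyl adds, so the size of its own contribution is unknown. Starting from the methoxy-removal step, a modest lowering of the number from compound 1 is expected, of about the size seen for compound 2, with wide uncertainty on either side because of a 2.7-fold lower number from compound 1 to compound 2 (0.44 log units; beyond the scatter) being the sole guide. The step expected is a 2.5-fold lower number from compound 1 to compound 3 (0.40 log units; beyond the scatter). Compound 3 is therefore estimated at 8000 nM in this assay, with a range from 2500 nM to 25000 nM.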

Compound 3, half-maximal inhibitory concentration: 1500 nM
Compound 3: the middle estimate sits 5.3-fold (0.73 log units) above what was measured; measured number outside the range, below it.
By their numbers in this assay, from the lowest: compound 3; then compound 2; then compound 1.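

The hydroxy group makes its own contribution at this site: in this assay, adding it to the unsubstituted phenyl ring gives a 4.9-fold lower number from compound 2 to compound 3 (0.69 log units; beyond the scatter), an effect the methoxy-removal step could not reveal. The full exchange of 3-methoxyphenyl for 4-hydroxyphenyl gives a 13-fold lower number from compound 1 to compound 3 (1.12 log units; beyond the scatter), so the substituent on this ring can move the number in either direction relative to the unsubstituted ring of compound 2, with the methoxy of compound 1 raising it and the hydroxy of compound 3 lowering it. No supporting data bear on the origin of either shift.

The compounds shown do not separate the identity of the substituent from its place on the ring, since the methoxy group appears only in 3-methoxyphenyl and the hydroxy group only in 4-hydroxyphenyl; 3-hydroxyphenyl and 4-methoxyphenyl would pull these two apart. Also open, going by these compounds, is whether the lower number is particular to hydroxy or extends to other groups on the same ring, such as an amine or a carboxylic acid in the place the hydroxy holds in compound 3.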